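The source may report more compounds than this note shows. Statements on the series, on what has been measured and on what is new or still open speak of the compounds shown alone.

Compound 1 `COc1ccccc1Oc1ccc2c(NCCCNCc3ccco3)ccnc2c1` gives 317 10^-6 cm/s in an ADME assay for permeability, using PAMPA, with a stated time of 30 min, at pH 7.4; on this read-out higher numbers stand for higher permeability and lower numbers for lower permeability. Compound 2 `c1ccc(-c2ccc3c(NCCCNCc4ccco4)ccnc3c2)cc1` gives 237 10^-6 cm/s in this assay, and compound 3 `COc1cccc(CNCCCNc2ccnc3cc(-c4ccccc4)ccc23)c1O` gives 237 10^-6 cm/s in this assay. The change 2-methoxyphenoxy in place of phenyl on an aromatic carbon produced a 1.3-fold higher number from compound 2 to compound 1 (0.13 log units; within the scatter), while the change 2-hydroxy-3-methoxyphenyl in place of furan-2-yl on a saturated chain carbon bound to an amine nitrogen produced no change at the digits printed from compound 2 to compound 3 (within the scatter). Compound 4 `COc1ccccc1Oc1ccc2c(NCCCNCc3cccc(OC)c3O)ccnc2c1` has not yet been measured in this assay. It differs from compound 3 by 2-methoxyphenoxy in place of phenyl on an aromatic carbon, the same change that takes compound 2 to compound 1, at a place described in the same words; the cores of compound 3 and compound 2 differ by 2-hydroxy-3-methoxyphenyl in place of furan-2-yl on a saturated chain carbon bound to an amine nitrogen. Since that change gave a 1.3-fold higher number from compound 2 to compound 1 (0.13 log units; within the scatter), a step of similar size is expected here, and for compound 4 the estimated step is a 1.3-fold higher number from compound 3 to compound 4 (0.10 log units; within the scatter). Compound 4 is therefore expected to give about 300 10^-6 cm/s in this assay, between 190 10^-6 cm/s and 470 10^-6 cm/s.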

Compound 4, apparent permeability: 317 10^-6 cm/s
Compound 4: middle estimate off by 1.1-fold (0.02 log units), on the low side; the range from low to high includes it.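

In this assay, 2-methoxyphenoxy in place of phenyl gave a 1.3-fold higher number from compound 3 to compound 4 (0.13 log units; within the scatter), which matches the step seen on the other core: the same change on two cores in this assay, a 1.3-fold higher number (0.13 log units; within the scatter) from compound 2 to compound 1 and a 1.3-fold higher number (0.13 log units; within the scatter) from compound 3 to compound 4, 1.0-fold (0.00 log units) apart, within the scatter of two such steps Likewise, 2-hydroxy-3-methoxyphenyl in place of furan-2-yl gave no change at the digits printed from compound 1 to compound 4 (within the scatter), again matching the earlier step: the same change on two cores in this assay, no change at the digits printed (within the scatter) from compound 2 to compound 3 and no change at the digits printed (within the scatter) from compound 1 to compound 4, 1.0-fold (0.00 log units) apart, within the scatter of two such steps Each change therefore carried from one core to the other here without a step beyond the scatter, but since all of these steps lie within the scatter, this does not show that either change moves the read-out, and two cores per change cannot establish a rule for the series.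

The compounds shown leave open whether a step beyond the scatter would appear with other groups. Examples are an amine or a carboxylic acid in place of 2-methoxyphenoxy, or a longer chain in place of the present one.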